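Swapping methyl for trifluoromethyl on an aromatic carbon

The source may report more compounds than this note shows. Statements on the series, on what has been measured and on what is new or still open speak of the compounds shown alone.

In a functional assay on HL-60 cells (Homo sapiens) for inhibition, read by MTT assay, with a stated time of 72 h (on this read-out higher numbers stand for weaker inhibition and lower numbers for stronger inhibition), compound 1 `Cc1nc(-c2ccc(F)cc2)c(C(=O)N2CCN(c3cccc(Cl)c3)CC2)o1` gives 40.1 nM and compound 2 `Cc1ccc(C)c(N2CCN(C(=O)c3oc(C)nc3-c3ccc(F)cc3)CC2)c1` gives 358 nM, which leaves compound 1 with the lower number and so the stronger inhibition of the pair. Compound 3 `O=C(c1oc(C(F)(F)F)nc1-c1ccc(F)cc1)N1CCN(c2cccc(Cl)c2)CC1` keeps the core of compound 1 but changes one group: trifluoromethyl in place of methyl on an aromatic carbon. Within the data shown here, the only measured step, an 8.9-fold higher number from compound 1 to compound 2 (0.95 log units; beyond the scatter), puts 2,5-dimethylphenyl in place of 3-chlorophenyl on an amine nitrogen in a ring, which is a different place in the molecule. Among the measured compounds shown here, that step shows that one change can move this number clearly, but no measured compound alters the methyl group, so its size and direction do not carry over. A small move is expected, leaning slightly toward a higher number, and the estimated step is a 1.7-fold higher number from compound 1 to compound 3 (0.24 log units; within the scatter). For compound 3 the expected value is 70 nM, with an estimated range from 15 nM to 300 nM.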

Compound 3, half-maximal inhibitory concentration: "not active" (no number reported)
Compound 3 has no reported number here; there is nothing to compare the estimate with.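

Among these compounds, compound 3 is reported as "not active" in this assay without a number, so no step from compound 1 to compound 3 can be read. No available evidence bears on this result. The compounds shown leave open how far trifluoromethyl in place of methyl moves the number.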